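Swapping the aryl group on the isoxazole of compound 2

The source may report more compounds than this note shows. Statements on the series, on what has been measured and on what is new or still open speak of the compounds shown alone.

Among the compounds with values here, compound 2 `N#Cc1ccc(-c2cc(COC(Cc3cn(C4CCN(Cc5ccc([N+](=O)[O-])cc5)CC4)nn3)c3ccc(Br)cc3)on2)cc1` stands lowest of the two numbers so far in a functional assay on MDA-MB-468 cells (Homo sapiens) for cytotoxicity, with a stated time of 48 h (a higher number here means a weaker inhibitor, a lower number a stronger inhibitor), with compound 2 giving 5000 nM; compound 1 `COc1ccc(-c2cc(COC(Cc3cn(C4CCN(Cc5ccc([N+](=O)[O-])cc5)CC4)nn3)c3ccc(Br)cc3)on2)cc1` gives 9000 nM, and the step of a 1.8-fold lower number from compound 1 to compound 2 (0.26 log units; within the scatter) is the only measured one. Compound 3 `O=[N+]([O-])c1ccc(CN2CCC(n3cc(CC(OCc4cc(-c5cccc(Br)c5)no4)c4ccc(Br)cc4)nn3)CC2)cc1` carries the change (3-bromophenyl in place of 4-cyanophenyl on an aromatic carbon). Within the data shown here, only that one step, a change at the same aryl group and within the scatter, bears on it, so no step beyond the scatter is expected for no change at the digits printed from compound 2 to compound 3 (within the scatter). Compound 3 is therefore estimated at 5000 nM in this assay, within 2000 nM to 12000 nM.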

Compound 3, half-maximal inhibitory concentration: > 25000 nM
Compound 3 was reported as a limit; the forecaster's own chance of this, stated with the estimate: 5%; middle value at least 5.0-fold (0.69 log units) from the limit.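

Compound 3 is reported only as a limit in this assay: the limit of > 25000 nM in this assay, at which 1 of the 3 values shown sits. The swap between 4-methoxyphenyl and 4-cyanophenyl stayed within the scatter, but 3-bromophenyl at this position gives steps beyond it, with an at least 5.0-fold higher number from compound 2 to compound 3 (0.69 log units; beyond the scatter) and an at least 2.7-fold higher number from compound 1 to compound 3 (0.44 log units; beyond the scatter). So this position does respond to a change of aryl group, although the limit leaves the full size of that response unknown.

As far as these compounds go, it remains open whether the step follows the bromine or its place on the ring; a 4-bromophenyl or a 3-cyanophenyl group would separate the two. From the compounds shown here alone, how an aminophenyl group would read here is also open.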